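This account rests on a few compounds, and the source may have more. Where it says the series, first, only, none or still open, it means among the compounds named here.

Measured compounds in a functional assay on KM12 cells (Homo sapiens) for inhibition, read by sulforhodamine B assay, with a stated time of 48 h, tested at 10 uM; a lower number here means a stronger effect, a higher number a weaker effect of the compound at the concentration tested:
compound 1, `COc1cc(Cl)cc(-c2nn(-c3cccc(NC(=O)c4ccc(Cl)c(Cl)c4)c3)cc2-c2ccncc2)c1`: 62.3%
compound 2, `COc1cc(Cl)cc(-c2nn(-c3cccc(NC(=O)Nc4ccc(Cl)c(C(F)(F)F)c4)c3)cc2-c2ccncc2)c1`: 9.1%
compound 3, `COc1cc(Cl)cc(-c2nn(-c3cccc(NC(=O)Nc4ccc(Cl)c(Cl)c4)c3)cc2-c2ccncc2)c1`: 14.4%

Compound 3 stands second highest of the three numbers; one step to it lies well beyond the scatter (a number 47.9 percentage points lower from compound 1 to compound 3 (beyond the scatter)) and the other stays within it (a number 5.3 percentage points higher from compound 2 to compound 3 (within the scatter)). Compound 4 is `COc1cc(Cl)cc(-c2nn(-c3cccc(NC(=O)Nc4cccc(C(F)(F)F)c4)c3)cc2-c2ccncc2)c1`; its change from compound 3 is 3-(trifluoromethyl)phenyl in place of 3,4-dichlorophenyl on an amide-type nitrogen. Among the compounds with values here, both urea compounds read low in this assay, the large steps being a number 53.2 percentage points lower from compound 1 to compound 2 (beyond the scatter) and a number 47.9 percentage points lower from compound 1 to compound 3 (beyond the scatter), while the only step among the ureas, a number 5.3 percentage points higher from compound 2 to compound 3 (within the scatter), stays within the scatter. Within the data shown here, no measured step removes the chloro alone, so the read-out of compound 4 is expected near compound 3, with a number 5.6 percentage points higher from compound 3 to compound 4 (within the scatter) not beyond the scatter. For compound 4 the estimate is 20%, range 5% to 45%.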

Compound 4, a percentage reported as activity, at one concentration (the size of the read-out at that concentration, not a potency): 9.81%
Compound 4: middle estimate off by 10.2 percentage points, on the high side, and the stated range covers the measured number.
By their numbers in this assay, from the lowest: compounds 2, 4 and 3 (each within the scatter of the next); then compound 1.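

In this assay, this amide-type nitrogen accepts 3-(trifluoromethyl)phenyl as readily as the two chloro-bearing rings: a number 4.6 percentage points lower from compound 3 to compound 4 (within the scatter), and losing the chloro alone gives a number 0.7 percentage points higher from compound 2 to compound 4 (within the scatter). The chloro therefore adds no readable effect alongside the trifluoromethyl here. The separation from the amide also persists with this third urea, a number 52.5 percentage points lower from compound 1 to compound 4 (beyond the scatter).

From the compounds shown here alone, whether an unsubstituted phenyl, or a ring carrying a methoxy or an amine, would read like these ureas stays open. No evidence on hand explains the similar readings among the ureas.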